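Chain extension beside an ester-bearing pyrrolidine amide

The compounds below may be only part of what the source reports. "The series", "measured", "known", "first", "only" and "open" are said of these compounds alone.

Measured compounds:
Compound 1, `CCCCc1nc(C)c(CC(=O)N(C)C)c(=O)n1Cc1ccc(-c2ccccc2-c2nnn[nH]2)cc1`: 0.018 mg/kg
Compound 2, `CCCCc1nc(C)c(CC(=O)N2CCC[C@H]2C(=O)OC)c(=O)n1Cc1ccc(-c2ccccc2-c2nnn[nH]2)cc1`: 0.043 mg/kg
Compound 3, `CCCCc1nc(C)c(CC(=O)N2CCN(C)CC2)c(=O)n1Cc1ccc(-c2ccccc2-c2nnn[nH]2)cc1`: "not determined" (no result reported)

The three compounds share one core and differ only in the group carried on the side chain. In an in vivo functional assay on the whole organism for inhibition, with Rattus norvegicus as the target (a higher number here means that more compound is needed for the effect, a lower number that less compound is needed), compound 1 gives 0.018 mg/kg, and compound 2 gives 0.043 mg/kg. Within the data shown here, the one measured step, a 2.4-fold higher number from compound 1 to compound 2 (0.38 log units; beyond the scatter), is modest. In this assay, from the compounds shown here alone, compound 3 gives "not determined" (no result reported), so its position among the others is unknown.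

Compound 4, `CCCCc1nc(C)c(CCC(=O)N2CCC[C@H]2C(=O)OC)c(=O)n1Cc1ccc(-c2ccccc2-c2nnn[nH]2)cc1`, is the unmeasured compound. It differs from compound 3 as follows: ((2-(methoxycarbonyl)pyrrolidin-1-yl)carbonyl)methyl in place of (4-methylpiperazin-1-yl)carbonyl on a saturated chain carbon bound to an aromatic carbon. Among the measured compounds shown here, no measured step bears directly on this change, since compound 3 has no value. The closest anchor is compound 2, which carries the same ester-bearing pyrrolidine amide and gives 0.043 mg/kg; compound 4 is expected to land near that value, with the step from compound 1 to compound 2 suggesting the range. Compound 4 is therefore estimated to give 0.06 mg/kg, within 0.015 mg/kg to 0.25 mg/kg.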

Compound 4, dose for half-maximal effect: 0.063 mg/kg
The estimate for compound 4 lay 1.1-fold (0.02 log units) below the measured number; the range from low to high includes it.
By their numbers in this assay, from the lowest: compound 1; then compounds 2 and 4 (each within the scatter of the next).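

In this assay the ((2-(methoxycarbonyl)pyrrolidin-1-yl)carbonyl)methyl group in place of (2-(methoxycarbonyl)pyrrolidin-1-yl)carbonyl gives a 1.5-fold higher number from compound 2 to compound 4 (0.17 log units; within the scatter) and so the longer chain on this saturated carbon leaves compound 4 indistinguishable from its shorter partner. Measured against the small dimethylcarbamoyl group, the same position shows a 3.5-fold higher number from compound 1 to compound 4 (0.54 log units; beyond the scatter) and this gap is only modest, so a larger group carrying the ester still leaves the dose needed in the same low range. No measurement shown here explains why these numbers fall as they do.

Steps involving compound 3 cannot be read, so the place of its (4-methylpiperazin-1-yl)carbonyl group remains unknown. From the compounds shown here alone, it also remains open whether the longer chain would behave alike with a dimethylamino amide, and whether a carboxylic acid in place of the methyl ester would keep the dose in this range.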